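The source may report more compounds than this note shows. Statements on the series, on what has been measured and on what is new or still open speak of the compounds shown alone.

Measured so far:
- compound 1, `COC(=O)c1cnc(C(=O)CCc2ccc(COc3ccccc3)cc2)o1`: 1.6 nM
- compound 2, `O=C(O)c1cc(-c2cnc(C(=O)CCc3ccc(-c4ccccc4)cc3)o2)ccn1`: 50 nM
- compound 3, `COC(=O)c1cccc(-c2cnc(C(O)CCc3ccc(-c4ccccc4)cc3)o2)n1`: 9000 nM

The three compounds were tested in an assay for inhibition of Fatty-acid amide hydrolase 1 (Rattus norvegicus); on this read-out lower numbers stand for stronger inhibition and higher numbers for weaker inhibition. Compound 1 gives 1.6 nM, compound 2 gives 50 nM, and compound 3 gives 9000 nM. Compound 2 therefore stands second highest of the three numbers; its nearest neighbour is compound 1, whose number is lower by a margin beyond the scatter, and the furthest is compound 3, whose number is higher by a margin far beyond the scatter. No pair among these three differs in only one place, so no single step between measured compounds can be read off.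

Compound 4, `CSc1cnc(C(=O)CCc2ccc(-c3ccccc3)cc2)o1`, has not yet been measured in this assay. It is derived from compound 2 by one change: methylsulfanyl in place of 2-carboxypyridin-4-yl on an aromatic carbon. The ketone and the biphenyl chain of compound 2 are kept.

Compound 1 shows that a small group on the same position of the core, together with the ketone, is compatible with a low number because of its value of 1.6 nM. On that basis the step from compound 2 to compound 4 is expected to be a modest move towards a lower number, of about a 2.5-fold lower number from compound 2 to compound 4 (0.40 log units; beyond the scatter), but it could also stay within the scatter. For compound 4 the estimate in this assay is 20 nM, with a range from 4 nM to 150 nM.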

Compound 4, inhibition constant: 3 nM
The estimate for compound 4 lay 6.7-fold (0.82 log units) above the measured number; the measured number lies below the stated range.
By their numbers in this assay, from the lowest: compounds 1 and 4 (each within the scatter of the next); then compound 2; then compound 3.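

In this assay, putting methylsulfanyl in place of 2-carboxypyridin-4-yl on the aromatic carbon next to the ring oxygen gives a 17-fold lower number from compound 2 to compound 4 (1.22 log units; beyond the scatter), a large step and the first that can be read at this position. The step shows that a low number at this position does not require the six-membered aromatic ring or its carboxylic acid, since compound 4, whose new group has only 2 heavy atoms, gives 3 nM with the ketone and the biphenyl chain of compound 2 kept. Nothing measured here explains why the number falls with this change.

This one step removes the ring and the carboxylic acid together and brings in the sulfur, so the share of each in the change cannot be separated. The compounds shown also leave open how this position would read with a bare hydrogen, a methoxy group, an amine or a longer chain such as ethylsulfanyl, and whether a carboxylic acid placed directly on the core would behave as the 2-carboxypyridin-4-yl group does.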